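Replacing 2-iodophenyl with 3-(trifluoromethyl)phenyl

The source may hold more compounds than are shown below. What is called first, only, known or untested is meant among the compounds shown, and "the series" means these compounds.

Compound 1 `COc1cc2ncnc(Nc3ccc(NC(=O)c4ccccc4C)cc3)c2cc1OC`: 15000 nM
Compound 2 `COc1cc2ncnc(Nc3ccc(NC(=O)c4ccccc4I)cc3)c2cc1OC`: 33000 nM

For the measured compounds named here, in a functional assay on HepG2 cells (Homo sapiens) for inhibition, read by MTT assay (on this read-out higher numbers stand for weaker inhibition and lower numbers for stronger inhibition), compound 2 gives 33000 nM as the higher of the two numbers measured so far. Compound 3 `COc1cc2ncnc(Nc3ccc(NC(=O)c4cccc(C(F)(F)F)c4)cc3)c2cc1OC` has 3-(trifluoromethyl)phenyl in place of 2-iodophenyl on a carbonyl carbon, and the count runs 3-(trifluoromethyl)phenyl in place of 2-iodophenyl on a carbonyl carbon in all. Going by the values given here, only one measured step bears on this, and it is modest: a 2.2-fold higher number from compound 1 to compound 2 (0.34 log units; beyond the scatter) is what the data show for a change to the group that compound 3 gives up. Among the compounds with values here, no measured compound carries trifluoromethyl, so this guide is indirect. A step no larger than that one is expected, toward a lower number. The estimate means a 1.8-fold lower number from compound 2 to compound 3 (0.26 log units; within the scatter) in this assay as the expected step. Compound 3 is estimated at 18000 nM (7000 nM to 45000 nM).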

Compound 3, half-maximal inhibitory concentration: 83000 nM
Beside the measured number, compound 3's estimate is 4.6-fold (0.66 log units) below it, outside the stated range (above it).
By their numbers in this assay, from the lowest: compound 1; then compound 2; then compound 3.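

The aryl group on this carbonyl carbon can move the number further than the first step suggested: in this assay the change to 3-(trifluoromethyl)phenyl gives a 2.5-fold higher number from compound 2 to compound 3 (0.40 log units; beyond the scatter) and a 5.5-fold higher number from compound 1 to compound 3 (0.74 log units; beyond the scatter). The three groups now span a wider range, with 2-methylphenyl giving the lowest number and 3-(trifluoromethyl)phenyl the highest, so compound 3 is the weakest inhibitor of the set. Nothing shown here explains why this change weakens inhibition.

This change alters both the substituent and its name-given place on the phenyl ring, so the compounds shown do not separate these two contributions. On these data alone, it remains open how 2-(trifluoromethyl)phenyl would compare with 3-(trifluoromethyl)phenyl, and whether an amine or a carboxylic acid on this ring would bring the number down.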